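This account rests on a few compounds, and the source may have more. Where it says the series, first, only, none or still open, it means among the compounds named here.

Measured so far:
compound 1 `CC(=O)NC[C@H]1CN(c2ccc(OC[C@@H](O)CNc3ccccc3)c(F)c2)C(=O)O1`: 124000 nM
compound 2 `CC(=O)NC[C@H]1CN(c2ccc(OC[C@@H](O)CNc3cccnc3)c(F)c2)C(=O)O1`: 3040000 nM

For the measured compounds named here, in a physicochemical assay for solubility, read by HPLC (a lower number here means a less soluble compound, a higher number a more soluble compound), compound 1 gives 124000 nM and stands as the lower of the two numbers available; the only neighbour is compound 2, reached by the step of a 25-fold higher number from compound 1 to compound 2 (1.39 log units; beyond the scatter), which is beyond the scatter and is the sole measured step in this set.

Compound 3 `CC(=O)NC[C@H]1CN(c2ccc(OC[C@H](O)CNc3ccncc3)c(F)c2)C(=O)O1` is the next compound to be measured. It differs from compound 1 as follows: 1-hydroxy-2-((pyridin-4-yl)amino)ethyl in place of 2-anilino-1-hydroxyethyl on a saturated chain carbon bound to an oxygen on an aromatic ring. Going by the values given here, no step for this exact change exists among the measured compounds. Among the compounds with values here, the one step that bears on it is the change from compound 1 to compound 2, where a six-membered aromatic ring of carbon only on the amine nitrogen was likewise exchanged for a six-membered aromatic ring with one hetero atom, and the result was a 25-fold higher number from compound 1 to compound 2 (1.39 log units; beyond the scatter). A change of the same kind, with the single hetero atom placed differently within the ring, is therefore expected to move in the same direction, that is a higher number in this assay, with a size judged uncertain given a single precedent.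

On that basis the step from compound 1 to compound 3 is estimated as a 16-fold higher number from compound 1 to compound 3 (1.21 log units; beyond the scatter). For compound 3 the expected value in this assay is 2000000 nM, with a range from 500000 nM to 6000000 nM.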

Compound 3, solubility: 24600000 nM
For compound 3 the middle estimate is 12-fold (1.09 log units) below the measured one, and the stated range ends below it.
By their numbers in this assay, from the lowest: compound 1; then compound 2; then compound 3.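

At this position, this assay now gives two exchanges of the carbon-only ring for a ring with one hetero atom, and both go the same way: a 25-fold higher number from compound 1 to compound 2 (1.39 log units; beyond the scatter) and a 200-fold higher number from compound 1 to compound 3 (2.30 log units; beyond the scatter). The two pyridinyl groups are not interchangeable, as an 8.1-fold higher number from compound 2 to compound 3 (0.91 log units; beyond the scatter) shows, but the defined stereocentre in the group is also written with the opposite sense in compound 3, so this step cannot be assigned to the placement of the ring nitrogen alone. No measurement available here accounts for the size of any of these steps.

Going by these compounds, the separate contributions of the ring nitrogen placement and the stereocentre remain open, and a pair of compounds differing in only one of these would separate them. Also open, on these data alone, is how far the trend across these three compounds extends to other groups on the amine nitrogen, such as a pyrimidin-5-yl ring with two ring nitrogens or a pyridin-2-yl ring, and whether a methyl group on that nitrogen would change the reading in this assay.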